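The source may hold more compounds than are shown below. What is called first, only, known or untested is meant among the compounds shown, and "the series" means these compounds.

Measured so far:
- compound 1, `COc1cc(Cl)cc(-c2nn(-c3cccc(NC(=O)Nc4cc(C(F)(F)F)cc(C(F)(F)F)c4)c3)cc2-c2ccncc2)c1`: 103%
- compound 2, `COc1cc(Cl)cc(-c2nn(-c3cccc(NC(=O)Nc4ccc(Cl)c(Cl)c4)c3)cc2-c2ccncc2)c1`: 96%

Both readings come from a functional assay on SK-MEL-2 cells (Homo sapiens) for inhibition, read by sulforhodamine B assay, with a stated time of 48 h, tested at 0.01 uM; a lower number here means a stronger effect, a higher number a weaker effect of the compound at the concentration tested. Compound 2 has the lower of the two numbers, but compound 1 lies only a few points higher, a gap within the usual scatter, so the two cannot be told apart. Both sit near the level at which the cells behave as if untreated at this concentration.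

Compound 3, `COc1cc(Cl)cc(-c2nn(-c3cccc(NC(=O)Nc4cccc(C(F)(F)F)c4)c3)cc2-c2ccncc2)c1`, shares the same core and differs from compound 2 in one place: 3-(trifluoromethyl)phenyl in place of 3,4-dichlorophenyl on an amide-type nitrogen. The group that leaves and the group that enters each consist of one six-membered aromatic ring of carbon only, with no hydrogen-bond donor or acceptor and no net charge.

Among the compounds with values here, no step between measured compounds is available, so any expectation rests on the two readings alone. Since compound 1 gives 103% and compound 2 gives 96%, the change is expected to produce no step beyond the scatter. The estimated step of a number 3 percentage points higher from compound 2 to compound 3 (within the scatter) therefore amounts to nothing beyond the scatter. Compound 3 is expected at 99%, within a range from 88% to 110%.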

Compound 3, a percentage reported as activity, at one concentration (the size of the read-out at that concentration, not a potency): 95%
For compound 3 the middle estimate is 4 percentage points above the measured one; the range from low to high includes it.
By their numbers in this assay, from the lowest: compounds 3, 2 and 1 (each within the scatter of the next).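

In this assay, within the data shown here, 3-(trifluoromethyl)phenyl in place of 3,4-dichlorophenyl on the amide-type nitrogen gives a number 1 percentage points lower from compound 2 to compound 3 (within the scatter), so this first direct swap at this position produces no step that can be read, even though the entering and leaving groups differ in their atoms and the aromatic ring is the only feature they share in the count of rings. Hydrogen in place of trifluoromethyl on an aromatic carbon gives a number 8 percentage points lower from compound 1 to compound 3 (within the scatter), which shows that having one trifluoromethyl group on this ring rather than two also leaves the reading within the scatter, so all three compounds remain indistinguishable at this single low concentration. No measurement shown here offers an explanation for these readings.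

Going by these compounds, the three compounds carry only chlorine or trifluoromethyl on the ring, so it remains open whether a carboxylic acid, a dimethylamino group or a longer alkyl chain at this place would shift the reading. On these data alone, it is also open whether these compounds would separate at higher concentrations, since a reading taken at one concentration cannot rank compounds that all sit close together.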